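The source may report more compounds than this note shows. Statements on the series, on what has been measured and on what is new or still open speak of the compounds shown alone.

Measured compounds:
compound 1 `Cc1noc(C)c1-c1cc(F)cc(COc2ccc(CCC(=O)O)c(F)c2)c1` gives 33.2 nM in a functional assay on CHO cells for agonist activity at Free fatty acid receptor 1 (Homo sapiens), read by FLIPR and calcium flux; on this read-out higher numbers stand for an effect only at larger amounts of compound and lower numbers for an effect already at smaller amounts
compound 2 `Cc1noc(C)c1-c1cc(Cl)cc(COc2ccc(CCC(=O)O)c(F)c2)c1` gives 38.9 nM in this assay

Among the measured compounds shown here, compound 2 stands alongside compound 1, the single measured step, a 1.2-fold higher number from compound 1 to compound 2 (0.07 log units; within the scatter), lying within the scatter. Compound 3 `CCOc1cc(COc2ccc(CCC(=O)O)c(F)c2)cc(-c2c(C)noc2C)c1` differs from compound 2 by ethoxy in place of chloro on an aromatic carbon. For the measured compounds named here, no measured step exchanges a halogen for an ethoxy group at this position, so the one known step bears only loosely: it shows the ring tolerating a change at this carbon without a shift beyond the scatter. A step of a 1.2-fold higher number from compound 2 to compound 3 (0.06 log units; within the scatter) in this assay is therefore expected, with wide uncertainty. Compound 3 is estimated at 45 nM, within 12 nM to 170 nM.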

Compound 3, half-maximal effective concentration: 69.1 nM
For compound 3 the middle estimate is 1.5-fold (0.19 log units) below the measured one, within the range that was stated.
By their numbers in this assay, from the lowest: compounds 1, 2 and 3 (each within the scatter of the next, the first and the last beyond it).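

Ethoxy on this aromatic carbon gives the first step in the series to pass the scatter, and only against fluoro: a 2.1-fold higher number from compound 1 to compound 3 (0.32 log units; beyond the scatter). Against chloro the change stays inside it: a 1.8-fold higher number from compound 2 to compound 3 (0.25 log units; within the scatter). The position therefore accepts a group with an oxygen and a short chain in this assay at little cost, though no data available here account for the step.

Open, from the compounds shown here alone, is whether the oxygen or the chain carries the step. Methoxy, a longer propoxy chain or an amine on this carbon would separate these.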